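A few compounds are considered here, and "the series" means these few. Any claim that something is new, unique, unknown or untested is made for them only; others in the source may bear on it.

Measured so far in an ADME assay on HepG2 cells (Homo sapiens) for cytotoxicity; a lower number here means that less compound is needed, a higher number that more compound is needed for the effect (each entry a limit of the assay)
- compound 1 `Cc1ccc(S(=O)(=O)N[C@@H](CC(=O)NC(C)(C)C)C(=O)NCCNC(=O)c2cccc(C(C)C)c2)cc1` gives > 11000 nM
- compound 2 `Cc1ccc(S(=O)(=O)N[C@@H](CC(=O)NC(C)(C)C)C(=O)NCCNC(=O)c2ccccc2F)cc1` gives > 11000 nM
- compound 3 `Cc1ccc(S(=O)(=O)N[C@@H](CC(=O)NC(C)(C)C)C(=O)NCCNC(=O)c2ccc(F)cc2)cc1` gives > 11000 nM

Compound 3 gives > 11000 nM as a limit and not a number. The next step leads to compound 4 `COc1cc(OC)cc(C(=O)NCCNC(=O)[C@H](CC(=O)NC(C)(C)C)NS(=O)(=O)c2ccc(C)cc2)c1` and puts 3,5-dimethoxyphenyl in place of 4-fluorophenyl on a carbonyl carbon. Going by the values given here, on this same carbonyl carbon the series offers a step that the two limits leave unreadable from compound 1 to compound 2 and a step that the two limits leave unreadable from compound 1 to compound 3 and a step that the two limits leave unreadable from compound 2 to compound 3 as its only steps, so no size is known for any of them. Among the compounds with values here, the expected outcome for compound 4 is a further limit because the limit of > 11000 nM in this assay, at which 3 of the 3 values shown sit, gives the only reading so far. No step beyond the scatter can be forecast in this assay and no direction can be given, so the expected step is a step that the limit leaves unreadable from compound 3 to compound 4 and rests on little. Compound 4 is estimated at 15000 nM with an expected range from 7000 nM to 40000 nM and will most likely be reported only as a limit.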

Compound 4, half-maximal effective concentration: > 11000 nM
Compound 4: no number, only a limit; the forecaster's own chance of this, stated with the estimate: 90%; the middle value does not contradict the limit.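

In this assay compound 4 gives > 11000 nM, a limit and not a number. Its steps from compound 1, compound 2 and compound 3 therefore cannot be read, and the reading stays at the limit: the limit of > 11000 nM in this assay, at which 4 of the 4 values shown sit. The compounds shown leave open whether any group on this carbonyl carbon shifts the read-out, and in which direction.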